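Ester to Amide and Back: Half-Life in Mouse Hepatocytes

The compounds below may be only part of what the source reports. "The series", "measured", "known", "first", "only" and "open" are said of these compounds alone.

Compound 1 `O=C(OC1CCC(CN2CCN(c3cc(=O)c4cc(C(F)(F)F)cc([N+](=O)[O-])c4s3)CC2)CC1)C1CCCCC1` gives 0.0783 h in an ADME assay on cells (Hepatocyte, Mus musculus) for metabolic stability; on this read-out lower numbers stand for a shorter-lived compound and higher numbers for a longer-lived compound.
Compound 2 `O=C(OC1CCC(CN2CCN(c3cc(=O)c4cc(C(F)(F)F)cc([N+](=O)[O-])c4s3)CC2)CC1)c1ccco1` gives < 0.075 h in this assay, a limit of the assay.
Compound 3 `CC(=O)NC1CCC(CN2CCN(c3cc(=O)c4cc(C(F)(F)F)cc([N+](=O)[O-])c4s3)CC2)CC1` gives > 1.55 h in this assay, a limit of the assay.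

Compound 3 stands at the top of what has been measured, and only as a limit: it sits at the limit of > 1.55 h in this assay, at which 1 of the 3 values shown sits, while compound 2 sits at the limit of < 0.075 h in this assay, at which 1 of the 3 values shown sits. Both ester-bearing compounds are short-lived, and the two steps that lead to the acetamido compound are large and in the same direction, an at least 19-fold higher number from compound 1 to compound 3 (1.29 log units; beyond the scatter) and an at least 20-fold higher number from compound 2 to compound 3 (1.31 log units; beyond the scatter). The difference between the esters themselves, an at least 1.0-fold lower number from compound 1 to compound 2 (0.01 log units; that floor lies within the scatter), lies within the scatter.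

Compound 4 `COc1ccc(C(=O)OC2CCC(CN3CCN(c4cc(=O)c5cc(C(F)(F)F)cc([N+](=O)[O-])c5s4)CC3)CC2)cc1` reverses this change: ((4-methoxyphenyl)carbonyl)oxy in place of acetamido on a saturated ring carbon. The steps from compound 1 and from compound 2 to compound 3 bear directly on it, run backwards, and both were large. A large step downward in this assay is therefore expected, an at least 19-fold lower number from compound 3 to compound 4 (1.28 log units; beyond the scatter). Compound 4 is expected to give about 0.08 h, in a range from 0.03 h to 0.3 h, close to where compound 1 and compound 2 stand.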

Compound 4, half-life: 0.295 h
Compound 4: the middle estimate sits 3.7-fold (0.57 log units) below what was measured, and the stated range covers the measured number.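

In this assay, the esters at this saturated ring carbon do not all sit at the same low level, since the group on the carbonyl carbon changes the read-out: a 3.8-fold higher number from compound 1 to compound 4 (0.58 log units; beyond the scatter) and an at least 3.9-fold higher number from compound 2 to compound 4 (0.59 log units; beyond the scatter), both with 4-methoxyphenyl as the entering group. Exchanging acetamido for ((4-methoxyphenyl)carbonyl)oxy still lowers the half-life, an at least 5.2-fold lower number from compound 3 to compound 4 (0.72 log units; beyond the scatter), so among the four compounds shown the acetamido compound remains apart from all three esters, yet the ester series itself now spans a step beyond the scatter. Compound 3 remains a limit of the assay and not a number, so the full size of that drop stays unknown: the limit of > 1.55 h in this assay, at which 1 of the 4 values shown sits.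

The compounds shown leave open whether the longer half-life of compound 4 among the esters goes with the benzene ring itself or with its methoxy group, a question that an unsubstituted phenyl or a 4-chlorophenyl on the same carbonyl carbon would address. They also leave open whether the high value of compound 3 belongs to the amide link or to its small acetyl part, which a cyclohexanecarboxamide or a 4-methoxybenzamide at this ring carbon would separate.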